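The source may hold more compounds than are shown below. What is called first, only, known or untested is meant among the compounds shown, and "the series" means these compounds.

Measured in a functional assay on MES-SA cells (Homo sapiens) for inhibition, with a stated time of 72 h; on this read-out higher numbers stand for weaker inhibition and lower numbers for stronger inhibition:
compound 1 `Oc1c(CN2CCCC2)ccc2cccnc12`: 4640 nM; 4570 nM (2 entries)
compound 2 `Oc1c(CN2CCCC2)cc(Br)c2cccnc12`: 3800 nM

The two entries for compound 1 agree closely: the several entries of compound 1 in this assay, 4640 nM; 4570 nM (2 entries). Compound 2 has a single number in this assay, 3800 nM, and a further entry for it gives no single number. That number lies within the usual scatter of the values for compound 1, so the two compounds cannot be told apart on this read-out.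

The next compound is compound 3 `COCc1cc(CN2CCCC2)c(O)c2ncccc12`. Methoxymethyl takes the place of bromo on an aromatic carbon, para to a hydroxy group and meta to a (pyrrolidin-1-yl)methyl group: methoxymethyl in place of bromo on an aromatic carbon. Going by the values given here, no measured step shows this exchange directly. The nearest guide is that compound 1, which carries no bromo, gives 4640 nM; 4570 nM (2 entries), while compound 2, which carries it, gives 3800 nM. On that basis, no change beyond the scatter is expected in this assay, and the expected 1.1-fold higher number from compound 2 to compound 3 (0.05 log units; within the scatter) has no firm direction. Compound 3 is estimated at 4300 nM, with an expected range of 1900 nM to 9500 nM.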

Compound 3, half-maximal inhibitory concentration: 11000 nM
Compound 3: the middle estimate sits 2.6-fold (0.41 log units) below what was measured; the whole stated range lies below it.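

With methoxymethyl in place of bromo on the aromatic carbon para to the hydroxy group, this assay gives a 2.9-fold higher number from compound 2 to compound 3 (0.46 log units; beyond the scatter). Going by these compounds alone, this is the first sign that the group at this position can shift the read-out, since compound 1 and compound 2 could not be told apart, and the number for compound 3, 11000 nM, is also higher than both entries for compound 1. None of the data shown explains why this exchange weakens inhibition.

Compound 3 is the only compound shown with a group of more than one heavy atom at this position, so the step cannot separate the effect of the ether oxygen from that of the added carbons or of losing bromo. On these data alone, how a plain methyl, a hydroxymethyl, a longer ether chain or an amine on this carbon would compare remains open, as does whether the shift holds with a group other than (pyrrolidin-1-yl)methyl on the core.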